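Cyclobutyl amine variation on the nitrile-bearing core

The source may hold more compounds than are shown below. What is called first, only, known or untested is meant among the compounds shown, and "the series" means these compounds.

Measured so far:
compound 1 `N#Cc1cnc(NCc2cnccc2C(F)(F)F)cc1N[C@H]1C[C@H](O)C1` gives 900 nM
compound 2 `N#Cc1cnc(NCc2ccccc2C(F)(F)F)cc1N[C@H]1CC[C@H](O)CC1` gives 4000 nM
compound 3 `COc1ncncc1CNc1cc(N[C@H]2CC[C@@H](O)CC2)c(C#N)cn1` gives 800 nM

All three values come from an assay on isolated protein for inhibition of protein kinase C theta type (Homo sapiens), read by TR-FRET, with a stated time of 2 h; a lower number here means a stronger inhibitor, a higher number a weaker inhibitor. Compound 1 holds the second highest of the three numbers; its nearest neighbour is compound 3, whose value sits within the scatter of compound 1, so no order between the two can be claimed. Compound 2 lies furthest away, with a number beyond the scatter above compound 1.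

The next compound, compound 4 `CC1(C)[C@H](Nc2cc(NCc3cnccc3C(F)(F)F)ncc2C#N)C[C@H]1C(N)=O`, keeps the shared core of compound 1 and changes only the substituent on the nitrogen on the aromatic ring: 3-carbamoyl-2,2-dimethylcyclobutyl in place of 3-hydroxycyclobutyl on a nitrogen on an aromatic ring. Going by the values given here, no measured pair in this small set covers a change of this kind, so nothing here tells the size of the step directly. The working expectation is a move toward lower numbers in this assay, of modest size, with wide uncertainty around it; the expected step of a 2.3-fold lower number from compound 1 to compound 4 (0.35 log units; beyond the scatter) reflects that. Compound 4 is estimated at 400 nM, within a range from 100 nM to 1600 nM.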

Compound 4, half-maximal inhibitory concentration: 140 nM
Beside the measured number, compound 4's estimate is 2.9-fold (0.46 log units) above it, and the stated range covers the measured number.
By their numbers in this assay, from the lowest: compound 4; then compounds 3 and 1 (each within the scatter of the next); then compound 2.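

In this assay, going by these compounds alone, the substituent on the nitrogen on the aromatic ring proves to be a place where the number responds: 3-carbamoyl-2,2-dimethylcyclobutyl in place of 3-hydroxycyclobutyl gives a 6.4-fold lower number from compound 1 to compound 4 (0.81 log units; beyond the scatter), the first step in this set that can be read across a single change. The four-membered ring and the counts of hydrogen-bond donors and acceptors stay the same, while the entering group carries more heavy atoms, so a larger group at this position is compatible with a lower number. No measured evidence accounts for the size of this step.

The compounds shown leave open whether the step belongs to the carbamoyl group or to the two methyl groups, since they change together here. From the compounds shown here alone, how a carboxylic acid or an amine in place of the carbamoyl group would read in this assay also remains open.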